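A Second Bromine on the Phenol Ring of Compound 2

A few compounds are considered here, and "the series" means these few. Any claim that something is new, unique, unknown or untested is made for them only; others in the source may bear on it.

In a functional assay on PC-3 cells (Homo sapiens) for cytotoxicity, read by MTT assay, with a stated time of 48 h (a lower number here means a stronger inhibitor, a higher number a weaker inhibitor), compound 1 `CC1=NN(C(=O)CCl)C(c2cc(Br)ccc2O)C1` gives 8890 nM. Compound 3 `CC1=NN(C(=O)CCc2ccccc2)C(c2cc(Br)ccc2O)C1` gives 16300 nM, and compound 2 `CC1=NN(C(=O)c2ccc(C)cc2)C(c2cc(Br)ccc2O)C1` gives 41200 nM, the highest number of the three: a 4.6-fold higher number from compound 1 to compound 2 (0.67 log units; beyond the scatter) and a 2.5-fold lower number from compound 2 to compound 3 (0.40 log units; beyond the scatter), both beyond the scatter, while a 1.8-fold higher number from compound 1 to compound 3 (0.26 log units; within the scatter) stays within it. Compound 4 `CC1=NN(C(=O)c2ccc(C)cc2)C(c2cc(Br)cc(Br)c2O)C1` differs from compound 2 by bromo in place of hydrogen on an aromatic carbon. None of the three measured steps bears on this change; each of them alters the group on the carbonyl carbon and leaves the aromatic ring bearing the hydroxy and bromo groups untouched, so the measured compounds give no guide to what a second bromo on that ring does. With nothing to lean on, the expectation for compound 4 is a number near that of compound 2, and the step of a 1.2-fold lower number from compound 2 to compound 4 (0.07 log units; within the scatter) is expected to lie within the scatter. The estimate for compound 4 is therefore 35000 nM, with a wide range from 12000 nM to 100000 nM reflecting that uncertainty.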

Compound 4, half-maximal inhibitory concentration: 41200 nM
The estimate for compound 4 lay 1.2-fold (0.07 log units) below the measured number, within the range that was stated.
By their numbers in this assay, from the lowest: compounds 1 and 3 (each within the scatter of the next); then compounds 2 and 4 (each within the scatter of the next).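

Among these compounds, this is the first reading on the ring bearing the hydroxy group, since every earlier step altered only the group on the carbonyl carbon. In this assay, bromo in place of hydrogen on the aromatic carbon ortho to a hydroxy group and meta to a bromo group gives no change at the digits printed from compound 2 to compound 4 (within the scatter) and leaves compound 2 and compound 4 indistinguishable, so with the 4-methylphenyl carbonyl group in place, this added heavy atom has no effect that can be read at this position. Nothing at hand offers an explanation for this result.

The compounds shown leave open whether a second bromo would behave the same way with the chloromethyl group of compound 1 or the phenethyl group of compound 3 on the carbonyl carbon. They also leave open what an amine or a carboxylic acid would do on this same aromatic carbon.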